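Aryl swap on the five-membered ring nitrogen: compound 3

The compounds below may be only part of what the source reports. "The series", "measured", "known", "first", "only" and "open" are said of these compounds alone.

Measured so far:
Compound 1 `Cc1ccc(C)c(-n2nncc2CN2C(=O)C3(C(C#N)=C(N)Oc4c(N)cc5nc6ccccc6nc5c43)c3ccccc32)c1` — in an ADME assay on L02 cells (Homo sapiens) for antiproliferative activity, read by MTT assay, with a stated time of 48 h (a higher number here means a weaker inhibitor, a lower number a stronger inhibitor), compound 1 gives > 50000 nM, a limit of the assay and not a number.
Compound 2 `N#CC1=C(N)Oc2c(N)cc3nc4ccccc4nc3c2C12C(=O)N(Cc1cnnn1-c1ccc([N+](=O)[O-])cc1[N+](=O)[O-])c1ccccc12` — in this assay compound 2 gives 22800 nM.

Compound 2 holds the only number shown in this assay for the series. The other value is a limit, that of compound 1 (the limit of > 50000 nM in this assay, at which 1 of the 2 values shown sits). Compound 3 `Cc1cc(C)c(-n2nncc2CN2C(=O)C3(C(C#N)=C(N)Oc4c(N)cc5nc6ccccc6nc5c43)c3ccccc32)c(C)c1` is not yet measured and differs from compound 2 in one place: 2,4,6-trimethylphenyl in place of 2,4-dinitrophenyl on an aromatic nitrogen.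

Within the data shown here, one measured step bears on this change: an at least 2.1-fold lower number from compound 1 to compound 2 (0.34 log units; beyond the scatter). That step brought in the 2,4-dinitrophenyl that compound 3 now removes; compound 3 instead carries 2,4,6-trimethylphenyl, a group of the same kind as the 2,5-dimethylphenyl of compound 1. Read in reverse, the step points to a higher number in this assay for compound 3, back toward the limit seen with compound 1, though the size of that measured step is itself bounded only on one side. Among the measured compounds shown here, the third methyl of the entering group has no measured counterpart here.

Compound 3 is therefore expected to give about 48000 nM in this assay, within 20000 nM to 120000 nM, an estimated step of a 2.1-fold higher number from compound 2 to compound 3 (0.32 log units; beyond the scatter) and a fair chance of again returning only a limit.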

Compound 3, half-maximal inhibitory concentration: > 50000 nM
Compound 3 was reported as a limit; the forecaster's own chance of this, stated with the estimate: 60%; middle value at least 1.0-fold (0.01 log units) away from the limit.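

Exchanging 2,4-dinitrophenyl for 2,4,6-trimethylphenyl on the aromatic nitrogen gives an at least 2.1-fold higher number from compound 2 to compound 3 (0.34 log units; beyond the scatter), so the difference first seen against the 2,5-dimethylphenyl of compound 1 recurs with a second methyl-bearing phenyl group. In this assay compound 3 gives > 50000 nM, a limit of the assay and not a number. Among these compounds, the step between compound 1 and compound 3 cannot be read, which leaves the third methyl and the altered methyl pattern without a measurable result, and compound 2 remains the only member of the series with a number rather than this limit: the limit of > 50000 nM in this assay, at which 2 of the 3 values shown sit.

The compounds shown do not separate the contribution of the two nitro groups from that of the missing methyl groups, nor do they show how far compound 1 and compound 3 would lie from compound 2 if their values could be read as numbers. A phenyl carrying a single nitro group, an aminophenyl or a carboxyphenyl on the same nitrogen would test whether the number of compound 2 depends on both nitro groups or on nitro at all.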